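A few compounds are considered here, and "the series" means these few. Any claim that something is new, unique, unknown or untested is made for them only; others in the source may bear on it.

Series notes. In a functional assay for agonist activity at thrombopoietin receptor (Homo sapiens) (on this read-out lower numbers stand for an effect already at smaller amounts and higher numbers for an effect only at larger amounts of compound), compound 1 `Nc1nc(-c2ccccc2F)cs1` gives 6800 nM, the highest number of the three measured. Compound 2 `Nc1nc(-c2cccc(OC(F)(F)F)c2F)cs1` gives 32 nM and compound 3 `Nc1nc(-c2cccc(C(F)(F)F)c2F)cs1` gives 57 nM. The change from compound 1 to compound 4 `Nc1nc(-c2ccc(C(F)(F)F)cc2F)cs1` is trifluoromethyl in place of hydrogen on an aromatic carbon. For the measured compounds named here, the measured steps that bear on it are a 120-fold lower number from compound 1 to compound 3 (2.08 log units; beyond the scatter) and a 210-fold lower number from compound 1 to compound 2 (2.33 log units; beyond the scatter); both add a fluorinated group to the same ring, but the place given for compound 4 is not the one probed by compounds 2 and 3, so those steps are a guide only. Between the two fluorinated groups the difference is a 1.8-fold higher number from compound 2 to compound 3 (0.25 log units; within the scatter). A lower number in this assay is expected for compound 4, though a smaller step than those measured, estimated as a 17-fold lower number from compound 1 to compound 4 (1.23 log units; beyond the scatter). Compound 4 is estimated at 400 nM, with a range from 60 nM to 3000 nM.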

Compound 4, half-maximal effective concentration: 260 nM
For compound 4 the middle estimate is 1.5-fold (0.19 log units) above the measured one; the range from low to high includes it.
By their numbers in this assay, from the lowest: compounds 2 and 3 (each within the scatter of the next); then compound 4; then compound 1.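

In this assay, trifluoromethyl on an aromatic carbon meta to a fluoro group and para to a group of 6 heavy atoms also lowers the number, with a 26-fold lower number from compound 1 to compound 4 (1.42 log units; beyond the scatter). The drop is thus not confined to one place on the ring, though this step is smaller than a 120-fold lower number from compound 1 to compound 3 (2.08 log units; beyond the scatter), where the same group enters elsewhere. No measurement shown accounts for this difference in step size. Open, as far as these compounds go, is whether an amine, a carboxylic acid or a methyl group at this place gives a comparable step.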